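The source may report more compounds than this note shows. Statements on the series, on what has been measured and on what is new or still open speak of the compounds shown alone.

Measured in a functional assay on MDA-MB-231 cells (Homo sapiens) for cytotoxicity, read by MTT assay, with a stated time of 48 h; on this read-out lower numbers stand for stronger inhibition and higher numbers for weaker inhibition:

- Compound 1 `COc1ccc(Nc2nc(-c3cccc(F)c3)nc3ccc(F)cc23)cc1` gives 47300 nM
- Compound 2 `Oc1ccccc1Nc1nc(-c2cccc(F)c2)nc2ccc(F)cc12` gives > 50000 nM (a limit)
- Compound 3 `Nc1cccc(Nc2nc(-c3cccc(F)c3)nc3ccc(F)cc23)c1` gives > 50000 nM (a limit)

Compound 3 has no exact number and stands only at a limit, > 50000 nM. The series is crowded there, with the limit of > 50000 nM in this assay, at which 2 of the 3 values shown sit. The move to compound 4 `Cc1ccc(Nc2nc(-c3cccc(F)c3)nc3ccc(F)cc23)cc1` is the change (4-methylphenyl in place of 3-aminophenyl on a nitrogen on an aromatic ring), which puts 4-methylphenyl in place of 3-aminophenyl on a nitrogen on an aromatic ring.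

Among the measured compounds shown here, three measured steps bear on this change. They read an at least 1.0-fold higher number from compound 1 to compound 3 (0.02 log units; that floor lies within the scatter), an at least 1.0-fold higher number from compound 1 to compound 2 (0.02 log units; that floor lies within the scatter) and a step that the two limits leave unreadable from compound 2 to compound 3. None of them shows a change beyond the scatter, so these exchanges on the nitrogen have not yet moved the read-out measurably. Compound 4 carries 4-methylphenyl, and the closest measured group is the 4-methoxyphenyl of compound 1, which gives 47300 nM. No step beyond the scatter is therefore expected in this assay, and the estimate is an at least 1.1-fold lower number from compound 3 to compound 4 (0.04 log units; that floor lies within the scatter). Compound 4 is estimated at 45000 nM, with an expected range from 18000 nM to 90000 nM.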

Compound 4, half-maximal inhibitory concentration: > 50000 nM
Compound 4: only a limit was reported (the forecaster's own chance of this, stated with the estimate: 55%); middle value at least 1.1-fold (0.04 log units) away from the limit.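

In this assay, the new result adds an exchange of methyl in place of methoxy on an aromatic carbon, which reads an at least 1.0-fold higher number from compound 1 to compound 4 (0.02 log units; that floor lies within the scatter). The steps joining compound 4 to compound 2 and compound 3 cannot be read, with limits at both ends. The 4-methylphenyl group thus brings no measurable gain, and the series gathers further at a single limit: the limit of > 50000 nM in this assay, at which 3 of the 4 values shown sit.

On these data alone, whether compound 2, compound 3 and compound 4 truly differ stays open, as their limits hide any real values. Also open, as far as these compounds go, is whether another group on the nitrogen, such as a phenyl ring carrying a carboxylic acid or a longer chain in place of the methyl, would give a value clearly beyond the scatter from compound 1.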